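The compounds below may be only part of what the source reports. "The series", "measured", "known", "first", "only" and "open" are said of these compounds alone.

Measured so far in an ADME assay on BHK cells (Mesocricetus auratus) for cytotoxicity, read by MTT assay, with a stated time of 96 h; a higher number here means that more compound is tolerated, a lower number that less compound is tolerated:
Compound 1 `O=C(CN1CCCCC1)Nc1ccc(-c2nc3cc(Cl)c(Cl)cc3[nH]2)cc1` gives 39000 nM.
Compound 2 `CN1CCN(CC(=O)Nc2ccc(-c3nc4cc(Cl)c(Cl)cc4[nH]3)cc2)CC1` gives 41000 nM.
Compound 3 `CC(=O)Nc1ccc(-c2nc3cc(Cl)c(Cl)cc3[nH]2)cc1` gives > 100000 nM, which is a limit of the assay and not a number.

Compound 3 thus stands only at the limit (the limit of > 100000 nM in this assay, at which 1 of the 3 values shown sits), with no number of its own. Compound 4 `O=C(CN1CCCC1)Nc1ccc(-c2nc3cc(Cl)c(Cl)cc3[nH]2)cc1` differs from it by pyrrolidin-1-yl in place of hydrogen on a saturated chain carbon bound to a carbonyl carbon. The measured steps that bear on this run in the opposite direction: an at least 2.5-fold higher number from compound 1 to compound 3 (0.40 log units; beyond the scatter) and an at least 2.4-fold higher number from compound 2 to compound 3 (0.38 log units; beyond the scatter), both beyond the scatter, while a 1.1-fold higher number from compound 1 to compound 2 (0.02 log units; within the scatter) lies within it. Restoring a ring amine at the same place is therefore expected to lower the number in this assay by a modest amount, bringing compound 4 back toward compounds 1 and 2. Compound 4 is estimated at 40000 nM, between 20000 nM and 100000 nM, an expected step of an at least 2.5-fold lower number from compound 3 to compound 4 (0.39 log units; beyond the scatter).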

Compound 4, half-maximal cytotoxic concentration: 64000 nM
For compound 4 the middle estimate is 1.6-fold (0.20 log units) below the measured one; the measured number falls inside the stated range.
By their numbers in this assay, from the lowest: compounds 1, 2 and 4 (each within the scatter of the next). At a limit, above all of these: compound 3.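

In this assay, a third ring amine on the saturated chain carbon bound to a carbonyl carbon joins the other two: a 1.6-fold higher number from compound 1 to compound 4 (0.22 log units; within the scatter) and a 1.6-fold higher number from compound 2 to compound 4 (0.19 log units; within the scatter), so pyrrolidin-1-yl, piperidin-1-yl and 4-methylpiperazin-1-yl are not told apart here. Against hydrogen the reading is an at least 1.5-fold lower number from compound 3 to compound 4 (0.19 log units; that floor lies within the scatter), so this ring amine alone does not establish a drop beyond the scatter. The value of compound 3 is a limit and not a number, so the full size of that step stays open: the limit of > 100000 nM in this assay, at which 1 of the 4 values shown sits.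

Open, on these data alone, is whether an open-chain dimethylamino group or a carboxylic acid at this place would track the ring amines or hydrogen. Also open, as far as these compounds go, is what a longer chain carrying pyrrolidin-1-yl would give.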